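Adding a Bromo Group to Compound 1

The source may hold more compounds than are shown below. What is called first, only, known or untested is meant among the compounds shown, and "the series" means these compounds.

Compound 1 `COc1ccccc1NC(=O)CN1CCN(S(=O)(=O)N2CCC(C)CC2)CC1` was examined in an assay on HEK293 cells for inhibition of potassium channel subfamily T member 1 (Homo sapiens), read by thallium flux; a lower number here means a stronger inhibitor, a higher number a weaker inhibitor. For compound 1 only a limit is known there, > 10000 nM, so its standing among the measured numbers is an upper bound rather than a point. Compound 2 `CC1CCN(S(=O)(=O)N2CCN(CC(=O)Nc3cc(Cl)ccc3OCC3CC3)CC2)CC1` gives 7500 nM in this assay. Compound 3 `COc1ccc(Br)cc1NC(=O)CN1CCN(S(=O)(=O)N2CCC(C)CC2)CC1` differs from compound 1 by bromo in place of hydrogen on an aromatic carbon. Going by the values given here, no measured pair isolates this change, so its direction remains open. The step from compound 1 to compound 3 is expected to be small, an at least 1.1-fold lower number from compound 1 to compound 3 (0.04 log units; that floor lies within the scatter). Compound 3 is estimated at 9000 nM, with a range from 3000 nM to 30000 nM.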

Compound 3, half-maximal inhibitory concentration: 1400 nM
The estimate for compound 3 lay 6.4-fold (0.81 log units) above the measured number; the measured number lies below the stated range.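

Bromo on the aromatic carbon para to the methoxy group is the first change at this position that can be read against compound 1, and in this assay it gives an at least 7.1-fold lower number from compound 1 to compound 3 (0.85 log units; beyond the scatter). The step lies beyond the scatter, so hydrogen to bromo at this carbon yields a stronger inhibitor. Compound 1 stands at a limit, so this size is a floor and not a measured step: the limit of > 10000 nM in this assay, at which 1 of the 3 values shown sits.

The compounds shown leave open whether fluoro, methyl or a nitrile on this same carbon would do the same. They also leave open whether bromo would act likewise on another carbon of the ring.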